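Swapping a chloro for a methoxy on the phenoxy ring

The compounds below may be only part of what the source reports. "The series", "measured", "known", "first", "only" and "open" are said of these compounds alone.

Measured compounds:
compound 1 `COc1ccc(Oc2c(/C=N\OCc3c(Cl)c(-c4ccc(F)cc4)nn3C)c(C)nn2C)cc1` — 2840 nM
compound 2 `Cc1nn(C)c(Oc2ccc(F)cc2)c1/C=N\OCc1c(Cl)c(-c2ccc(Cl)cc2)nn1C` — 4430 nM
compound 3 `Cc1nn(C)c(Oc2ccc(Cl)cc2)c1/C=N\OCc1c(Cl)c(-c2ccc(Cl)cc2)nn1C` — 7510 nM

In a functional assay on SGC-7901 cells (Homo sapiens) for antiproliferative activity, read by MTT assay, with a stated time of 72 h (a lower number here means a stronger inhibitor, a higher number a weaker inhibitor), compound 3 gives the highest number of the three. Its gap to compound 2 is within the scatter, while compound 1 sits a little further down, beyond it. Compound 4 `COc1ccc(Oc2c(/C=N\OCc3c(Cl)c(-c4ccc(Cl)cc4)nn3C)c(C)nn2C)cc1` is not yet measured; it differs from compound 3 by methoxy in place of chloro on an aromatic carbon. Among the measured compounds shown here, the only measured single change on this ring is a 1.7-fold higher number from compound 2 to compound 3 (0.23 log units; within the scatter), too small to read as a trend. Compound 1, which carries the same methoxy as compound 4, shows the lowest number, so a modest move toward lower values is expected: a 2.0-fold lower number from compound 3 to compound 4 (0.30 log units; within the scatter). Compound 4 is estimated at 3800 nM, within a range of 1500 nM to 9000 nM.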

Compound 4, half-maximal inhibitory concentration: 2010 nM
Beside the measured number, compound 4's estimate is 1.9-fold (0.28 log units) above it; the measured number falls inside the stated range.
By their numbers in this assay, from the lowest: compounds 4, 1, 2 and 3 (each within the scatter of the next, the first and the last beyond it).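

At the 4-methoxyphenoxy end, methoxy in place of chloro gives a 3.7-fold lower number from compound 3 to compound 4 (0.57 log units; beyond the scatter) in this assay and methoxy in place of fluoro gives a 2.2-fold lower number from compound 2 to compound 4 (0.34 log units; beyond the scatter) so this position responds to the group it carries, which compound 2 and compound 3 alone could not show. On the other ring, chloro in place of fluoro gives a 1.4-fold lower number from compound 1 to compound 4 (0.15 log units; within the scatter) and so shows no clear effect. Swapping fluoro for chloro stays small in both places it can be read: the same change on two cores in this assay, a 1.7-fold higher number (0.23 log units; within the scatter) from compound 2 to compound 3 and a 1.4-fold lower number (0.15 log units; within the scatter) from compound 1 to compound 4, 2.4-fold (0.38 log units) apart, within the scatter of two such steps. Still open, going by these compounds, is how an amine, a hydroxyl or a longer ether chain would behave at the phenoxy position.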